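The compounds below may be only part of what the source reports. "The series", "measured", "known", "first", "only" and "open" are said of these compounds alone.

Compound 1 `C/C(=C\CC/C(C)=C/CC[C@@H]1[C@@]2(C)CCC(=O)C(C)(C)[C@H]2CC[C@@]1(C)O)CC/C=C(\C)C(=O)OCc1cn(-c2ccccc2C(F)(F)F)nn1` is the reference point of this pair of notes. In a functional assay on A549 cells (Homo sapiens) for antiproliferative activity, read by MTT assay, with a stated time of 48 h (on this read-out lower numbers stand for stronger inhibition and higher numbers for weaker inhibition), compound 1 returns only a limit, > 150000 nM, and no number. Compound 2 `C/C(=C\CC/C(C)=C/CC[C@@H]1[C@@]2(C)CCC(=O)C(C)(C)[C@H]2CC[C@@]1(C)O)CC/C=C(\C)C(=O)OCc1cn(-c2ccccc2Cl)nn1` differs from compound 1 in one place, with chloro in place of trifluoromethyl on an aromatic carbon. In this assay compound 2 also returns only a limit, > 150000 nM. The step that the two limits leave unreadable from compound 1 to compound 2 thus cannot be sized, since (the limit of > 150000 nM in this assay, at which 2 of the 2 values shown sit). Compound 3 `C/C(=C\CC/C(C)=C/CC[C@@H]1[C@@]2(C)CCC(=O)C(C)(C)[C@H]2CC[C@@]1(C)O)CC/C=C(\C)C(=O)OCc1cn(-c2ccccc2F)nn1` has not been measured in this assay; it differs from compound 1 as follows: fluoro in place of trifluoromethyl on an aromatic carbon. Among the measured compounds shown here, the only measured step that touches this part of the structure is the one from compound 1 to compound 2, and it is unreadable, so there is nothing measured here that would point to a change beyond the scatter. For compound 3 the expected step in this assay is a step that the limit leaves unreadable from compound 1 to compound 3, with the most likely outcome being that compound 3 again returns only a limit. For compound 3 the estimate in this assay is 200000 nM, within 60000 nM to 600000 nM.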

Compound 3, half-maximal inhibitory concentration: > 150000 nM
Compound 3: a limit, no number; the forecaster's own chance of this, stated with the estimate: 80%; the middle value does not contradict the limit.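

Compound 3 returns only a limit in this assay and no number, so no step can be read from compound 1 to compound 3 or from compound 2 to compound 3: the limit of > 150000 nM in this assay, at which 3 of the 3 values shown sit. The compounds shown leave open whether trifluoromethyl, chloro or fluoro on the aromatic carbon makes any difference to the read-out.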